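Notes on the series: from compound 2 to compound 3

The source may hold more compounds than are shown below. What is called first, only, known or untested is meant among the compounds shown, and "the series" means these compounds.

The series is measured in a functional assay (Homo sapiens) for inhibition, read by luminescence, with a stated time of 72 h; on this read-out lower numbers stand for stronger inhibition and higher numbers for weaker inhibition. Compound 1 `CSc1nccc(N2CCC(N(C)Cc3ccccc3Cl)CC2)n1` gives 1700 nM in this assay. Compound 2 `CSc1nccc(N2CCC(N(C)Cc3c(F)cccc3Cl)CC2)n1`, which carries a fluoro in place of a hydrogen on an aromatic carbon, gives 940 nM in this assay. For the measured compounds named here, of the two numbers so far, that of compound 2 is the one at the bottom, but the step of a 1.8-fold lower number from compound 1 to compound 2 (0.26 log units; within the scatter) is within the scatter, so the two compounds cannot be told apart on this evidence.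

Compound 3 `CSc1nccc(N2CCC(N(C)Cc3ccc(Cl)cc3Cl)CC2)n1` is not yet measured. It differs from compound 2 by 2,4-dichlorophenyl in place of 2-chloro-6-fluorophenyl on a saturated chain carbon bound to an amine nitrogen. Going by the values given here, no measured step exchanges one substituted ring for another; the only step known, a 1.8-fold lower number from compound 1 to compound 2 (0.26 log units; within the scatter), concerns a single added fluoro and stayed within the scatter. It bears on compound 3 only in that a change of the halogen pattern on this ring has so far not moved the number beyond the scatter. For compound 3 no step beyond the scatter is therefore expected in this assay, in either direction, and the estimate is set near the two measured values. Compound 3 is expected to give 1300 nM in this assay, within a range from 500 nM to 3500 nM. The expected step is a 1.4-fold higher number from compound 2 to compound 3 (0.14 log units; within the scatter).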

Compound 3, half-maximal inhibitory concentration: 1680 nM
Beside the measured number, compound 3's estimate is 1.3-fold (0.11 log units) below it; the measured number falls inside the stated range.
By their numbers in this assay, from the lowest: compounds 2, 3 and 1 (each within the scatter of the next).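

In this assay, for the compounds shown here, the step of a 1.8-fold higher number from compound 2 to compound 3 (0.25 log units; within the scatter) is the first exchange of one substituted ring for another on a saturated chain carbon bound to an amine nitrogen, and on this evidence 2,4-dichlorophenyl cannot be told apart from 2-chloro-6-fluorophenyl. The step of a 1.0-fold lower number from compound 1 to compound 3 (0.01 log units; within the scatter), an added chloro on the ring, also stays within the scatter; with compound 2, this makes two halogen additions to the ring of compound 1, and neither can be told apart from it. No measurement is available that would help interpret these results.

The compounds shown carry only chloro and fluoro on this ring, and it remains open whether a methoxy, a nitrile or an amine there would give a step beyond the scatter. Going by these compounds alone, every step so far also sits on this one ring, and it remains open whether a change elsewhere on the shared core, such as a longer chain in place of the methyl on the amine nitrogen, would move the number further.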